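The source may hold more compounds than are shown below. What is called first, only, known or untested is meant among the compounds shown, and "the series" means these compounds.

Measured in an ADME assay on microsomes from liver (Mus musculus, strain CD1) for metabolic stability, read by HPLC, with a stated time of 30 min, tested at 1 uM; on this read-out lower numbers stand for slow clearance and higher numbers for fast clearance:
- Compound 1 `Cn1cc2c(NS(=O)(=O)c3ccc(Br)cc3)cccc2n1`: 6.3 mL.min-1.g-1
- Compound 2 `O=S(=O)(Nc1c(C2CCCCC2)ccc2ncccc12)c1ccc(Br)cc1`: 38 mL.min-1.g-1
- Compound 3 `CC(C)Cc1ccc2ncccc2c1NS(=O)(=O)c1ccc(Br)cc1`: > 50 mL.min-1.g-1

Compound 3 gives only a limit of the assay, > 50 mL.min-1.g-1, and no number. Compound 4 `O=S(=O)(Nc1c(Cc2ccccc2)ccc2ncccc12)c1ccc(Br)cc1` differs from it by phenyl in place of isopropyl on a saturated chain carbon bound to an aromatic carbon, or isobutyl to benzyl. Among the compounds with values here, the one measured step that bears on this change is an at least 1.3-fold higher number from compound 2 to compound 3 (0.11 log units; that floor lies within the scatter). Taken with that step, compound 2 at 38 mL.min-1.g-1 points to fast clearance for compound 4 as well, so no change beyond the scatter is expected in this assay. The estimated step is an at least 1.2-fold lower number from compound 3 to compound 4 (0.09 log units; that floor lies within the scatter). Compound 4 is expected at 40 mL.min-1.g-1, within an estimated range of 20 mL.min-1.g-1 to 70 mL.min-1.g-1.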

Compound 4, intrinsic clearance in microsomes: 23 mL.min-1.g-1
Estimate against measurement, compound 4: 1.7-fold (0.24 log units) above; the range from low to high includes it.
By their numbers in this assay, from the lowest: compound 1; then compounds 4 and 2 (each within the scatter of the next). At a limit, above all of these: compound 3.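

In this assay, within the data shown here, phenyl in place of isopropyl on a saturated chain carbon bound to an aromatic carbon gives an at least 2.1-fold lower number from compound 3 to compound 4 (0.33 log units; beyond the scatter), the one step at this place that clears the scatter. Compound 3 enters that step only as a limit of the assay: the limit of > 50 mL.min-1.g-1 in this assay, at which 1 of the 4 values shown sits. Swapping the cyclohexyl group for benzyl gives a 1.7-fold lower number from compound 2 to compound 4 (0.22 log units; within the scatter), so compound 2 and compound 4 cannot be told apart. Going by these compounds, how far compound 3 lies past its limit stays open. So does whether an amine or a carboxylic acid on the phenyl of the benzyl group would shift clearance at all.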